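The source may report more compounds than this note shows. Statements on the series, on what has been measured and on what is new or still open speak of the compounds shown alone.

In a functional assay on MCF7 cells (Homo sapiens) for inhibition, read by MTT assay, with a stated time of 72 h (a higher number here means a weaker inhibitor, a lower number a stronger inhibitor), compound 3 `C=CC(=O)Nc1cccc(Oc2nc(Nc3cccc(C#N)c3)nc3ccsc23)c1` gives 19000 nM. Compound 1 `C=CC(=O)Nc1cccc(Oc2nc(Nc3cccc(OC)c3)nc3ccsc23)c1` gives 19000 nM, and no change at the digits printed from compound 1 to compound 3 (within the scatter) leaves the two level, together the highest of the three numbers; compound 2 `C/C=C/C(=O)Nc1cccc(Oc2nc(Nc3cccc(OC)c3)nc3ccsc23)c1` gives 14600 nM. Compound 4 `C/C=C/C(=O)Nc1cccc(Oc2nc(Nc3cccc(C#N)c3)nc3ccsc23)c1` differs from compound 3 by prop-1-en-1-yl in place of vinyl on a carbonyl carbon. Among the compounds with values here, the one measured step of this kind, a 1.3-fold lower number from compound 1 to compound 2 (0.11 log units; within the scatter), lay within the scatter, so from compound 3 to compound 4 no step beyond the scatter is expected in this assay, though a small drift in the same direction would not surprise. Compound 4 is therefore expected to give about 15000 nM in this assay, with a range of 7000 nM to 32000 nM. That estimate corresponds to an expected step of a 1.3-fold lower number from compound 3 to compound 4 (0.10 log units; within the scatter).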

Compound 4, half-maximal inhibitory concentration: 33100 nM
Estimate against measurement, compound 4: 2.2-fold (0.34 log units) below; measured number outside the range, above it.
By their numbers in this assay, from the lowest: compounds 2, 1, 3 and 4 (each within the scatter of the next, the first and the last beyond it).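

In this assay, prop-1-en-1-yl in place of vinyl on a carbonyl carbon gives a 1.7-fold higher number from compound 3 to compound 4 (0.24 log units; within the scatter), so this change now stands on two cores without a step beyond the scatter, and its two readings fit together: the same change on two cores in this assay, a 1.3-fold lower number (0.11 log units; within the scatter) from compound 1 to compound 2 and a 1.7-fold higher number (0.24 log units; within the scatter) from compound 3 to compound 4, 2.3-fold (0.36 log units) apart, within the scatter of two such steps

Cyano in place of methoxy on an aromatic carbon gives a 2.3-fold higher number from compound 2 to compound 4 (0.36 log units; beyond the scatter), the first step in this set beyond the scatter, though it is modest and its gap from the same change on the other core stays within the scatter: the same change on two cores in this assay, no change at the digits printed (within the scatter) from compound 1 to compound 3 and a 2.3-fold higher number (0.36 log units; beyond the scatter) from compound 2 to compound 4, 2.3-fold (0.36 log units) apart, within the scatter of two such steps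

From the compounds shown here alone, with a single pair for each reading, it stays open whether these two changes depend on each other. Going by these compounds, how a longer chain or an amine in place of prop-1-en-1-yl on that carbonyl carbon would read in this assay also stays open.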